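The source may report more compounds than this note shows. Statements on the series, on what has been measured and on what is new or still open speak of the compounds shown alone.

Compound 1 `Oc1ccc(/C=C/c2ccccc2O)cc1` and compound 2 `COc1cccc(/C=C/c2ccccc2O)c1` are built on cores whose difference is not broken down here. In a functional assay on MCF7 cells (Homo sapiens) for inhibition, read by MTT assay, with a stated time of 2 days (on this read-out lower numbers stand for stronger inhibition and higher numbers for weaker inhibition), compound 1 gives 21 ug/mL, and compound 2 gives 18 ug/mL; the two values lie within the usual scatter of each other. Compound 3 `Nc1ccc(/C=C/c2ccccc2O)cc1` differs from compound 1 by amino in place of hydroxy on an aromatic carbon, and in this assay compound 3 gives 23 ug/mL, a step of a 1.1-fold higher number from compound 1 to compound 3 (0.04 log units; within the scatter). Compound 4 `COc1cccc(/C=C/c2ccccc2N)c1` differs from compound 2 by the same kind of change, (amino in place of hydroxy on an aromatic carbon); here the place is ortho to a large group, whereas in compound 3 it is para to a group of 9 heavy atoms. Because the earlier step was a 1.1-fold higher number from compound 1 to compound 3 (0.04 log units; within the scatter), the expected step is a 1.1-fold higher number from compound 2 to compound 4 (0.05 log units; within the scatter). Compound 4 is therefore estimated at 20 ug/mL, with the likely range running from 10 ug/mL to 40 ug/mL.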

Compound 4, half-maximal inhibitory concentration: 6.1 ug/mL
The estimate for compound 4 lay 3.3-fold (0.52 log units) above the measured number; the measured number lies below the stated range.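

Amino in place of hydroxy, ortho to a large group, gives a 3.0-fold lower number from compound 2 to compound 4 (0.47 log units; beyond the scatter) in this assay, a modest move towards stronger inhibition. The same change therefore does not carry over at one size between these two cores: the same change on two cores in this assay, a 1.1-fold higher number (0.04 log units; within the scatter) from compound 1 to compound 3 and a 3.0-fold lower number (0.47 log units; beyond the scatter) from compound 2 to compound 4, 3.2-fold (0.51 log units) apart, beyond the scatter of two such steps

This rests on one pair for each core, and the change also sits in a different place on each. It shows that the step cannot simply be transferred here, but not which difference between the pairs is responsible.

The compounds shown leave open whether a methylamino group or a fluorine atom in that place would follow amino. They also leave open whether amino would give a similar step on further cores.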